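The source may hold more compounds than are shown below. What is called first, only, known or untested is meant among the compounds shown, and "the series" means these compounds.

Measured compounds:
Compound 1, `CCCCCCCCCCC(C)(C)NC(=O)c1c(OC)cc(OC)cc1OC`, gives in an assay on microsomes from liver for inhibition of sterol O-acyltransferase 1 (Rattus norvegicus) (on this read-out lower numbers stand for stronger inhibition and higher numbers for weaker inhibition), only the assay limit > 10000 nM, which is not a number.
Compound 2, `CCCCCCCCCCCCn1nnc(C(NC(=O)c2ccc(Cl)cc2)c2ccccc2)n1`, gives in this assay 440 nM.

Among the compounds with values here, compound 2 thus holds the only real number among the two results; the other result is the limit (the limit of > 10000 nM in this assay, at which 1 of the 2 values shown sits). Within the data shown here, no step between the two measured compounds can be read, since they differ in more than one place.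

Compound 3, `CCCCCCCCCCCCn1nnc(C(NC(=O)c2ccc(C(F)(F)F)cc2)c2ccccc2)n1`, is not yet measured. It departs from compound 2 by trifluoromethyl in place of chloro on an aromatic carbon. For a swap of this kind the two measured compounds offer no guide, so the change from compound 2 to compound 3 in this assay is expected to stay within the usual scatter, with no clear direction. Compound 3 is therefore estimated at 400 nM, within a range from 150 nM to 1100 nM. The step this implies, a 1.1-fold lower number from compound 2 to compound 3 (0.04 log units; within the scatter), is expected to be small.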

Compound 3, half-maximal inhibitory concentration: 850 nM
Estimate against measurement, compound 3: 2.1-fold (0.33 log units) below; measured number inside the range.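

In this assay, putting trifluoromethyl in place of chloro on the aromatic carbon para to a large group gives a 1.9-fold higher number from compound 2 to compound 3 (0.29 log units; within the scatter). Within the data shown here, this is the first step that can be read at this position, and it shows that the two compounds cannot be told apart in this assay, even though the entering group has 4 heavy atoms and the leaving group has 1. Nothing measured here explains the result.

Only these two groups are shown at this position, so it remains open whether an amine, a carboxylic acid or a plain hydrogen there would give a step beyond the scatter. From the compounds shown here alone, it is also open how changes elsewhere in the molecule, such as a shorter chain on the shared core, would affect the number.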